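A few compounds are considered here, and "the series" means these few. Any claim that something is new, unique, unknown or untested is made for them only; others in the source may bear on it.

Of the compounds shown here, three built on a shared core have been tested in an ADME assay on microsomes from liver (Homo sapiens) for metabolic stability, with a stated time of 10 min, tested at 0.5 uM (on this read-out higher numbers stand for a more stable compound and lower numbers for a less stable compound), and their values spread widely: compound 1 `C[C@H](NC(=O)[C@H](C)[C@H]1CC[C@@H](c2ccnc3ccc(F)cc32)CC1)c1ccc(Cl)cc1` stands at 19% while compound 2 `C[C@@H](NCc1ccc(Cl)cc1)[C@H]1CC[C@@H](c2ccnc3ccc(F)cc32)CC1` stands at 34% and compound 3 `C[C@@H](CNC(=O)c1ccc(Cl)cc1)[C@H]1CC[C@@H](c2ccnc3ccc(F)cc32)CC1` stands at 56% in the same test. Compound 2 therefore holds the middle place, with its gaps to both of the others beyond the scatter. Compound 4 `C[C@@H](NC(=O)C1CCCCC1)[C@H]1CC[C@@H](c2ccnc3ccc(F)cc32)CC1` has not been measured yet. Its difference from compound 2 is cyclohexylcarbonyl in place of 4-chlorobenzyl on an amine nitrogen and in short this means cyclohexylcarbonyl in place of 4-chlorobenzyl on an amine nitrogen. Within the data shown here, no measured pair shows this change on its own. Compound 1 at 19% and compound 3 at 56% both carry a carbonyl, yet they fall on opposite sides of compound 2 and so give no clear direction. The expected step is small and slightly upward, an estimated a number 4 percentage points higher from compound 2 to compound 4 (within the scatter) that stays within the scatter. For compound 4 the estimated value is 38% with an expected range from 15% to 62% in this test.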

Compound 4, percent of the compound remaining: 6%
For compound 4 the middle estimate is 32 percentage points above the measured one, outside the stated range (below it).
By their numbers in this assay, from the lowest: compound 4; then compound 1; then compound 2; then compound 3.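

In this assay, among these compounds, putting cyclohexylcarbonyl in place of 4-chlorobenzyl on an amine nitrogen gives a number 28 percentage points lower from compound 2 to compound 4 (beyond the scatter), and this is the first view of this change on its own. The position is therefore not indifferent to what it carries, even though the two groups hold the same number of heavy atoms and each contains a six-membered ring of carbon only. The swap alters several features at once, since the ring stops being aromatic, the chlorine is lost and a carbonyl appears, and this single step does not show which of these matters.

Nothing shown here explains the fall in stability. Still open, going by these compounds, is how a cyclohexylmethyl group, with this ring but no carbonyl, or a benzoyl group, with a carbonyl and an aromatic ring, would read on the same nitrogen.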